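The compounds below may be only part of what the source reports. "The series", "measured", "known", "first", "only" and "open" are said of these compounds alone.

Compound 1 `Cc1ccc(NC(=S)NC(=O)c2ccc(OCc3ccc(C(F)(F)F)cc3)cc2)cc1-c1nc2ccccc2[nH]1` gives 72400 nM.
Compound 2 `O=C(NC(=S)Nc1ccc(Cl)c(-c2nc3ccccc3[nH]2)c1)c1ccc(OCc2ccc(C(F)(F)F)cc2)cc1` gives 63900 nM.
Compound 3 `Cc1ccc(NC(=O)NC(=O)c2ccc(OCc3ccccc3F)cc2)cc1-c1nc2ccccc2[nH]1` gives 4110 nM.

All three values come from a functional assay on SW-620 cells (Homo sapiens) for inhibition, read by MTT assay, with a stated time of 48 h; a higher number here means a weaker inhibitor, a lower number a stronger inhibitor. Compound 1 and compound 2 share one core and differ only by chloro in place of methyl on an aromatic carbon; that change gave a 1.1-fold lower number from compound 1 to compound 2 (0.05 log units; within the scatter), so the two compounds cannot be told apart here. Compound 3 has a different core; the difference between the core of compound 1 and the core of compound 3 is not broken down here. Compound 3 has the lowest number of the three, and its gaps to compound 1 and to compound 2 both lie beyond the scatter.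

Compound 4 `O=C(NC(=O)c1ccc(OCc2ccccc2F)cc1)Nc1ccc(Cl)c(-c2nc3ccccc3[nH]2)c1` has not yet been measured. Among the measured compounds shown here, it differs from compound 3 by chloro in place of methyl on an aromatic carbon, which is the same change, at the same place, as the one from compound 1 to compound 2. Because that earlier step was a 1.1-fold lower number from compound 1 to compound 2 (0.05 log units; within the scatter), the step of a 1.1-fold lower number from compound 3 to compound 4 (0.03 log units; within the scatter) is expected to be small as well. Compound 4 is therefore estimated to give 3800 nM in this assay, with a likely range from 1500 nM to 9500 nM.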

Compound 4, half-maximal inhibitory concentration: 2930 nM
Compound 4: the middle estimate sits 1.3-fold (0.11 log units) above what was measured; the measured number falls inside the stated range.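

Putting chloro in place of methyl gave a 1.4-fold lower number from compound 3 to compound 4 (0.15 log units; within the scatter) in this assay, so compound 3 and compound 4 cannot be told apart here. Set side by side, the two steps do not differ, and the change carried over from one core to the other with little effect on the number: the same change on two cores in this assay, a 1.1-fold lower number (0.05 log units; within the scatter) from compound 1 to compound 2 and a 1.4-fold lower number (0.15 log units; within the scatter) from compound 3 to compound 4, 1.2-fold (0.09 log units) apart, within the scatter of two such steps. This supports a modest rule for these two cores in this one assay, namely that methyl and chloro at this place can be treated as interchangeable, but two pairs cannot show that the same would hold on any other core or in any other test.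

The compounds shown have only methyl and chloro at this place, so it remains open what a hydrogen, a methoxy group, a nitrile or an amine would do there. On these data alone, it also remains open whether the swap would stay this small in other cell lines.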